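Replacing the Phenyl of Compound 2 with Methoxymethyl

The source may hold more compounds than are shown below. What is called first, only, known or untested is meant among the compounds shown, and "the series" means these compounds.

Compound 1, `O=C(O)CCCSCCN1C(=O)OC[C@@H]1/C=C/[C@@H](O)Cc1ccccc1`, gives 36 nM in a functional assay on CHO cells for agonist activity at prostaglandin E2 receptor EP4 subtype (Rattus norvegicus), read by cAMP accumulation and immunoassay, with a stated time of 10 min; on this read-out lower numbers stand for an effect already at smaller amounts and higher numbers for an effect only at larger amounts of compound.
Compound 2, `O=C(O)CCCSCCN1C(=O)OC[C@@H]1/C=C/[C@@H](O)Cc1cccc(-c2ccccc2)c1`, gives 450 nM in this assay.
Compound 3, `O=C(O)CCCSCCN1C(=O)SC[C@@H]1/C=C/[C@@H](O)Cc1ccccc1`, gives 4.8 nM in this assay.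

Among these three, compound 2 stands at the highest number in this assay; compound 1 is its nearest neighbour, with a lower number beyond the scatter, and compound 3 lies furthest away, lower still. Compound 4, `COCc1cccc(C[C@H](O)/C=C/[C@H]2COC(=O)N2CCSCCCC(=O)O)c1`, is not yet measured. It differs from compound 2 by methoxymethyl in place of phenyl on an aromatic carbon. Going by the values given here, only one measured step bears on this change: a 13-fold higher number from compound 1 to compound 2 (1.10 log units; beyond the scatter), in which putting a phenyl onto that aromatic carbon raised the number by a large amount. Among the compounds with values here, compound 4 removes that same phenyl and puts a methoxymethyl in its place, a group for which no measured pair here gives guidance. The expected outcome is therefore a return toward the number of compound 1, with a step of a 7.5-fold lower number from compound 2 to compound 4 (0.88 log units; beyond the scatter), though the unknown contribution of the methoxymethyl leaves the range wide. Compound 4 is estimated at 60 nM, with a range from 18 nM to 250 nM.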

Compound 4, half-maximal effective concentration: 24 nM
Compound 4: middle estimate off by 2.5-fold (0.40 log units), on the high side; the measured number falls inside the stated range.
By their numbers in this assay, from the lowest: compound 3; then compounds 4 and 1 (each within the scatter of the next); then compound 2.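

On this aromatic carbon, the high number of compound 2 does not hold for every added group: methoxymethyl in place of phenyl gives a 19-fold lower number from compound 2 to compound 4 (1.27 log units; beyond the scatter) in this assay and so undoes the large rise. Set against hydrogen on the same carbon, methoxymethyl gives a 1.5-fold lower number from compound 1 to compound 4 (0.18 log units; within the scatter), so this substituent leaves the number indistinguishable from hydrogen, whereas phenyl gave a 13-fold higher number from compound 1 to compound 2 (1.10 log units; beyond the scatter). Nothing measured here explains why these two groups differ.

Going by these compounds, whether the rise belongs to an aromatic ring on this carbon or to something else remains open, and a hydroxymethyl, an aminomethyl or a pyridine ring in this place would help to separate these possibilities. On these data alone, it is also open whether methoxymethyl would leave the number of compound 3 just as unchanged on the core of compound 3.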